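The source may report more compounds than this note shows. Statements on the series, on what has been measured and on what is new or still open speak of the compounds shown alone.

In a functional assay on A549 cells (Homo sapiens) for cytotoxicity, read by MTT assay, with a stated time of 72 h (a lower number here means a stronger inhibitor, a higher number a weaker inhibitor), compound 1 (`O=C1c2c[n+]([O-])c3ccccc3c2C(=O)c2c1c1ccccc1n2Cc1cn(C[C@H](O)CO)nn1`) gives 1030 nM as its half-maximal inhibitory concentration. On the same read-out compound 2 (`CN1CCN(CCCCn2c3c(c4ccccc42)C(=O)c2c[n+]([O-])c4ccccc4c2C3=O)CC1`) gives 90 nM and compound 3 (`CCCN1CCN(CCCCn2c3c(c4ccccc42)C(=O)c2c[n+]([O-])c4ccccc4c2C3=O)CC1`) gives 320 nM as the middle number of the three. The modest 3.2-fold lower number from compound 1 to compound 3 (0.51 log units; beyond the scatter) falls short of the large 11-fold lower number from compound 1 to compound 2 (1.06 log units; beyond the scatter) on the same scale.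

Compound 4 (`CN1CCN(CCCn2c3c(c4ccccc42)C(=O)c2c[n+]([O-])c4ccccc4c2C3=O)CC1`) has not yet been measured. The change from compound 3 (4-methylpiperazin-1-yl in place of (4-propylpiperazin-1-yl)methyl on a saturated chain carbon, three bonds along the chain from an aromatic nitrogen) puts 4-methylpiperazin-1-yl in place of (4-propylpiperazin-1-yl)methyl on a saturated chain carbon, three bonds along the chain from an aromatic nitrogen. The measured step that bears on this most directly is a 3.6-fold higher number from compound 2 to compound 3 (0.55 log units; beyond the scatter) and it is modest, and compound 4 shares the 4-methylpiperazin-1-yl group of compound 2. Going by the values given here, no measured pair shows the chain part of this change alone, so that part remains open. A modest step towards a lower number is therefore expected in this assay for this change. The expected step is a 2.5-fold lower number from compound 3 to compound 4 (0.39 log units; beyond the scatter) on this estimate. Compound 4 is expected at 130 nM within an estimated range from 45 nM to 380 nM on this reading.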

Compound 4, half-maximal inhibitory concentration: 140 nM
Beside the measured number, compound 4's estimate is 1.1-fold (0.03 log units) below it, within the range that was stated.
By their numbers in this assay, from the lowest: compounds 2 and 4 (each within the scatter of the next); then compound 3; then compound 1.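

In this assay, going by these compounds alone, the pair of compound 2 and compound 4 gives the first reading of the chain change alone: a 1.6-fold higher number from compound 2 to compound 4 (0.19 log units; within the scatter). The other two steps stay beyond the scatter: a 2.3-fold lower number from compound 3 to compound 4 (0.36 log units; beyond the scatter), a step that changes both the chain and the group on the piperazine, and a 7.4-fold lower number from compound 1 to compound 4 (0.87 log units; beyond the scatter), so the 2-(4-methylpiperazin-1-yl)ethyl group also stands well apart from the triazole-bearing group of compound 1, as the longer chain of compound 2 did. Nothing available explains any of these steps.

Going by these compounds, the effect of the chain on the propyl series remains open, since a 2-(4-propylpiperazin-1-yl)ethyl group would be needed to separate the two parts of the step to compound 4 from compound 3. Also open, on these data alone, is how the number would respond at this place to a piperazine with hydrogen in place of methyl, to a morpholine, or to a chain longer than the 3-(4-methylpiperazin-1-yl)propyl group.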